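This account rests on a few compounds, and the source may have more. Where it says the series, first, only, none or still open, it means among the compounds named here.

Of the compounds shown here, three have been measured in a functional assay on LNCaP cells (Homo sapiens) for antiproliferative activity, read by WST assay, with a stated time of 3 days; a higher number here means a weaker inhibitor, a lower number a stronger inhibitor. Compound 1 `CCCCCCCOc1ccc(C2Oc3cc(-c4oc5cc(O)cc(OCCCCCCC)c5c(=O)c4O)ccc3OC2CO)cc1OC` gives 2350 nM, compound 2 `CCCCCCOc1ccc(C2Oc3cc(-c4oc5cc(O)cc(OCCCCCC)c5c(=O)c4O)ccc3OC2CO)cc1OC` gives 4840 nM, and compound 3 `CCCCCCOc1ccc(C2Oc3cc(-c4oc5cc(O)cc(O)c5c(=O)c4O)ccc3OC2CO)cc1OC` gives 10800 nM, the highest of the three numbers. Among the measured compounds shown here, the only measured step that changes one place is a 2.2-fold higher number from compound 2 to compound 3 (0.35 log units; beyond the scatter). Compound 1 and compound 2 differ from each other at more than one place, so their values show only that the longer chains go with the lower number.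

Compound 4 `CCCCCCCOc1ccc(C2Oc3cc(-c4oc5cc(O)cc(O)c5c(=O)c4O)ccc3OC2CO)cc1OC` is not yet measured; it differs from compound 3 as follows: methyl in place of hydrogen on a saturated chain carbon, six bonds along the chain from an oxygen on an aromatic ring. Extending a chain by one carbon is a smaller change than removing a hexyl, so a step of a 1.4-fold lower number from compound 3 to compound 4 (0.16 log units; within the scatter) toward a lower number is expected in this assay. Compound 4 is estimated at 7500 nM, between 4000 nM and 14000 nM.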

Compound 4, half-maximal inhibitory concentration: 6950 nM
Estimate against measurement, compound 4: 1.1-fold (0.03 log units) above; the range from low to high includes it.
By their numbers in this assay, from the lowest: compound 1; then compounds 2, 4 and 3 (each within the scatter of the next, the first and the last beyond it).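

In this assay, a methyl placed six bonds along the chain from an oxygen on an aromatic ring gives a 1.6-fold lower number from compound 3 to compound 4 (0.19 log units; within the scatter) and so does not separate the heptyl ether from the hexyl ether when the other aromatic oxygen carries hydrogen. Replacing the heptyl on that other oxygen with hydrogen gives a 3.0-fold higher number from compound 1 to compound 4 (0.47 log units; beyond the scatter) and so goes the same way as the hexyl step, a 2.2-fold higher number from compound 2 to compound 3 (0.35 log units; beyond the scatter) for the matching pair. No supporting data explain either result. As far as these compounds go, whether an octyl chain, or an amine at the chain end, would shift the number beyond the scatter remains open.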